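Chloro in Place of Hydrogen Across Two Anticonvulsant Amide Series

The compounds below may be only part of what the source reports. "The series", "measured", "known", "first", "only" and "open" are said of these compounds alone.

Measured compounds:
compound 1, `O=C(CCC(=O)c1ccccc1)Nc1nc2ccc(F)cc2s1`, 300 mg/kg
compound 2, `O=C(CCC(=O)c1ccccc1)Nc1nc2cc(Cl)c(F)cc2s1`, 300 mg/kg
compound 3, `O=C(Nc1nc2ccc(F)cc2s1)c1ccccc1C(=O)c1ccccc1`, 100 mg/kg

The three measured compounds were tested in a functional assay on the whole organism with Mus musculus as the target, in the maximal electroshock model, with a stated time of 4 h; on this read-out lower numbers stand for an effect already at smaller amounts and higher numbers for an effect only at larger amounts of compound. Compound 1 gives 300 mg/kg in this assay. Compound 2 differs from compound 1 by one change, (chloro in place of hydrogen on an aromatic carbon), and in this assay compound 2 gives 300 mg/kg. The step is no change at the digits printed from compound 1 to compound 2 (within the scatter), so the added chloro left the read-out where it was.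

Compound 3 carries a different amide part; how its core differs from the core of compound 1 is not broken down here. In this assay compound 3 gives 100 mg/kg, the lowest of the three numbers, and its steps to compound 1 and to compound 2 both lie beyond the scatter.

Compound 4, `O=C(Nc1nc2cc(Cl)c(F)cc2s1)c1ccccc1C(=O)c1ccccc1`, has not yet been measured. It differs from compound 3 by chloro in place of hydrogen on an aromatic carbon. The place of the entering chloro is described in the same words as for the change from compound 1 to compound 2, so this is the same change applied to the core of compound 3.

Compound 4 is therefore expected to give 100 mg/kg. For compound 4 the expected step is no change at the digits printed from compound 3 to compound 4 (within the scatter), which rests on the earlier step of no change at the digits printed from compound 1 to compound 2 (within the scatter), where the same chloro produced no change within the scatter. Compound 4 is expected to fall between 50 mg/kg and 300 mg/kg, the wider range allowing for the possibility that the change behaves differently on this core.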

Compound 4, minimum effective dose: 300 mg/kg
For compound 4 the middle estimate is 3.0-fold (0.48 log units) below the measured one, and the stated range covers the measured number.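

In this assay, chloro in place of hydrogen on the aromatic carbon ortho to a fluoro group gave a 3.0-fold higher number from compound 3 to compound 4 (0.48 log units; beyond the scatter), whereas the same change on the other core gave no change at the digits printed from compound 1 to compound 2 (within the scatter). Going by these compounds alone, the change therefore did not carry over from one core to the other with the same result in this small series, and the gap between the two steps is larger than chance scatter would readily account for: the same change on two cores in this assay, no change at the digits printed (within the scatter) from compound 1 to compound 2 and a 3.0-fold higher number (0.48 log units; beyond the scatter) from compound 3 to compound 4, 3.0-fold (0.48 log units) apart, beyond the scatter of two such steps This shows that the result of adding this chloro cannot simply be read across between these two cores, but with only one pair on each core, it does not show what in the differing amide part separates them, nor how the change would behave on any further core.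

The compounds shown leave open whether a bromo or a methoxy group entering at the same aromatic carbon would separate the two cores in the same way as chloro. They also leave open whether the chloro step would follow either pattern on a core with a longer chain in the amide part, or on one with hydrogen in place of the fluoro group.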